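The source may hold more compounds than are shown below. What is called first, only, known or untested is meant among the compounds shown, and "the series" means these compounds.

Compound 2 `C[C@@H]1CCCN1c1c(C#N)c2c(N)nc(Nc3cn(C)nc3Cl)nc2n1C` gives 34 nM in an assay on isolated protein for inhibition of Leucine-rich repeat serine/threonine-protein kinase 2 (Homo sapiens), read by TR-FRET and LanthaScreen, with stated times of 50 min and 30 min, in the presence of a further agent that is not named here (a lower number here means a stronger inhibitor, a higher number a weaker inhibitor), the lowest of the three numbers in hand. Within the data shown here, compound 1 `CN(C)c1c(C#N)c2c(N)ncnc2n1C` gives 4620 nM and compound 3 `Cn1c(N)c(C#N)c2c(N)ncnc21` gives 14400 nM; the one measured step, a 3.1-fold higher number from compound 1 to compound 3 (0.49 log units; beyond the scatter), concerns the shared core and not the group that changes here. Compound 4 `Cc1c(Nc2nc(N)c3c(C#N)c(N4CCC[C@H]4C)n(C)c3n2)cnn1C` differs from compound 2 in one place: 1,5-dimethyl-1H-pyrazol-4-yl in place of 3-chloro-1-methyl-1H-pyrazol-4-yl on a nitrogen on an aromatic ring. Among the measured compounds shown here, no measured pair speaks to an exchange of one pyrazolyl for another, so the direction of the step cannot be read from the data; a change this small on a group of the same size is expected to stay near the scatter. Compound 4 is therefore expected to give 50 nM (range 15 nM to 170 nM), a step of a 1.5-fold higher number from compound 2 to compound 4 (0.17 log units; within the scatter).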

Compound 4, half-maximal inhibitory concentration: 75 nM
For compound 4 the middle estimate is 1.5-fold (0.18 log units) below the measured one, and the stated range covers the measured number.
By their numbers in this assay, from the lowest: compound 2; then compound 4; then compound 1; then compound 3.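

In this assay, among these compounds, the exchange of 3-chloro-1-methyl-1H-pyrazol-4-yl for 1,5-dimethyl-1H-pyrazol-4-yl gives a 2.2-fold higher number from compound 2 to compound 4 (0.34 log units; beyond the scatter) and is the first measured change at this group. On this one pair, the number on this nitrogen responds modestly to replacing one pyrazolyl with another of the same heavy-atom count. Nothing at hand bears on why the number rises. As far as these compounds go, whether the loss of the chlorine or the gain of the methyl governs the step stays open. So does the effect of 1-methyl-1H-pyrazol-4-yl, carrying neither, or of a phenyl ring here.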